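From diethylamino to azido in an antiproliferative series

A few compounds are considered here, and "the series" means these few. Any claim that something is new, unique, unknown or untested is made for them only; others in the source may bear on it.

Three related compounds have been tested in a functional assay on SW480 cells (Homo sapiens) for antiproliferative activity, read by MTT assay, with a stated time of 48 h; on this read-out lower numbers stand for stronger inhibition and higher numbers for weaker inhibition. Compound 2 `CCN(CC)C/C1=C/C[C@](C)(CCC=C(C)C)/C=C/[C@@H](OC(=O)C=C(C)C)[C@](C)(O)/C=C/C1=O` gives 270 nM, the lowest number of the three and so the strongest inhibition. Compound 1 `CO[C@]1(C)/C=C/C(=O)/C(CO)=C\C[C@](C)(CCC=C(C)C)/C=C/[C@H]1OC(=O)C=C(C)C` gives 15200 nM and compound 3 `CC(C)=CCC[C@]1(C)/C=C/[C@@H](OC(=O)C=C(C)C)[C@](C)(O)/C=C/C(=O)/C(C[Si](c2ccccc2)(c2ccccc2)C(C)(C)C)=C\C1` gives 20700 nM. These two lie within the usual scatter of each other, while compound 2 lies well beyond the scatter from both.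

The next molecule is compound 4 `CC(C)=CCC[C@]1(C)/C=C/[C@@H](OC(=O)C=C(C)C)[C@](C)(O)/C=C/C(=O)/C(CN=[N+]=[N-])=C\C1`, which changes one group of compound 2: azido in place of diethylamino on a saturated chain carbon bound to a double-bonded ring carbon. In plain terms, the diethylamino group gives way to azido, and the rest of the structure stays as it is. Among the compounds with values here, no two measured compounds differ in just one place, so no direct step can guide the forecast. Of the three, only compound 2 carries diethylamino, while compound 1 at 15200 nM and compound 3 at 20700 nM lack it. Three compounds are too few for a rule, but they suggest a large rise in the number in this assay, beyond the scatter. The expected change is a 22-fold higher number from compound 2 to compound 4 (1.35 log units; beyond the scatter). In this assay the estimated value for compound 4 is 6000 nM, with an expected range from 1500 nM to 20000 nM.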

Compound 4, half-maximal inhibitory concentration: 4230 nM
Beside the measured number, compound 4's estimate is 1.4-fold (0.15 log units) above it, and the stated range covers the measured number.
By their numbers in this assay, from the lowest: compound 2; then compound 4; then compounds 1 and 3 (each within the scatter of the next).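

Within the data shown here, for the first time, two measured compounds differ in one place only, so the change from (diethylamino)methyl to azidomethyl can be read directly. In this assay, azido in place of diethylamino on a saturated chain carbon bound to a double-bonded ring carbon gives a 16-fold higher number from compound 2 to compound 4 (1.19 log units; beyond the scatter), so the group at this position has a large effect on the number even with the rest of the structure unchanged. The change weakens inhibition without abolishing it, as compound 4 gives 4230 nM in this test, and no measurement shown accounts for the rise.

A single pair cannot show whether the low number of compound 2 is particular to diethylamino or would also be seen with a smaller amine such as dimethylamino, or with a ring amine such as morpholine or piperidine. It also leaves open whether swapping the same two groups would produce a step of similar size if other parts of the shared core were different.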